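Compound 3 to compound 4: a sulfur-bearing ring swap

The source may report more compounds than this note shows. Statements on the series, on what has been measured and on what is new or still open speak of the compounds shown alone.

Measured in a functional assay on DU-145 cells (Homo sapiens) for antiproliferative activity, read by MTT assay, with a stated time of 72 h; a higher number here means a weaker inhibitor, a lower number a stronger inhibitor:
- compound 1 `CC(C)(C)C#Cc1cc(-c2ccc(/C=C/C(=O)O)cc2Cl)ccc1O`: > 10000 nM, a limit
- compound 2 `Cc1cccc(C)c1-c1cc(-c2ccc(/C=C/C(=O)O)cc2Cl)ccc1O`: > 10000 nM, a limit
- compound 3 `CC1(c2cc(-c3ccc(/C=C/C(=O)O)cc3Cl)ccc2O)CCCCC1`: 8000 nM

Compound 3 is the only one of the three with a number, 8000 nM. The other two values are the limit of > 10000 nM in this assay, at which 2 of the 3 values shown sit, so the series offers little to rank against.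

Compound 4 `CC1(c2cc(-c3ccc(/C=C/C(=O)O)cc3Cl)ccc2O)SCCCS1` has not been measured. It differs from compound 3 by a group of 7 heavy atoms (5 carbon, 2 sulfur; one six-membered non-aromatic ring with 2 hetero atoms) in place of a group of 7 heavy atoms (7 carbon; one six-membered non-aromatic ring of carbon only), on an aromatic carbon. The change sits on an aromatic carbon, ortho to a hydroxy group and meta to a large group.

The three measured steps all replace the group at this same carbon. Among the measured compounds shown here, the first is a step that the two limits leave unreadable from compound 1 to compound 2. The second is an at least 1.2-fold lower number from compound 1 to compound 3 (0.09 log units; that floor lies within the scatter). The third is an at least 1.2-fold lower number from compound 2 to compound 3 (0.09 log units; that floor lies within the scatter). None of them is readable beyond the scatter, so they give no basis for expecting a real shift in this assay, in either direction. The expected step is no change at the digits printed from compound 3 to compound 4 (within the scatter), which amounts to none beyond the scatter. A report of compound 4 as a limit only is a real possibility, given (the limit of > 10000 nM in this assay, at which 2 of the 3 values shown sit).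

For compound 4 the estimated value is 8000 nM, with an expected range from 3500 nM to 18000 nM.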

Compound 4, half-maximal inhibitory concentration: > 20000 nM
Compound 4 ended at the assay's limit; the forecaster's own chance of this, stated with the estimate: 45%; at least 2.5-fold (0.39 log units) between middle value and limit.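

In this assay, among the compounds shown here, the group on this aromatic carbon, ortho to a hydroxy group, now gives a readable step for the first time: an at least 2.5-fold higher number from compound 3 to compound 4 (0.39 log units; beyond the scatter). Compound 4 is reported only as a limit, > 20000 nM. The exchange keeps the heavy-atom count of the group and the six-membered ring, while a ring of carbon only gives way to a ring with 2 hetero atoms, so this position responds to the make-up of the ring even at a matched group size, which the earlier replacements, all unreadable or within the scatter, could not show.

The steps from compound 1 and from compound 2 to compound 4 cannot be read, and the true size of the step from compound 3 stays unknown, because each of these comparisons ends at a limit: the limit of > 20000 nM in this assay, at which 1 of the 4 values shown sits.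
From the compounds shown here alone, how much of the step belongs to the sulfur atoms themselves stays open, and a six-membered ring with oxygen in place of sulfur, or an amine in the ring, would bear on that.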